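An aryl swap on the ring nitrogen of compound 3

A few compounds are considered here, and "the series" means these few. Any claim that something is new, unique, unknown or untested is made for them only; others in the source may bear on it.

In a functional assay on DU-145 cells (Homo sapiens) for cytotoxicity, read by sulforhodamine B assay, with a stated time of 48 h (a lower number here means a stronger inhibitor of growth, a higher number a weaker inhibitor of growth), compound 1 `CN1CCN(c2nc(Nc3ccc(C#N)c(C(F)(F)F)c3)nc(Oc3ccnc4ccccc34)n2)CC1` gives 51200 nM. Compound 2 `CCN1CCN(c2nc(Nc3ccc(C#N)c(C(F)(F)F)c3)nc(Oc3ccnc4ccccc34)n2)CC1` gives 86600 nM, and the step of a 1.7-fold higher number from compound 1 to compound 2 (0.23 log units; within the scatter) stays within the scatter. Compound 3 `COc1ccc(N2CCN(c3nc(Nc4ccc(C#N)c(C(F)(F)F)c4)nc(Oc4ccnc5ccccc45)n3)CC2)cc1` reaches only a limit of the assay, > 100000 nM. Compound 3 therefore stands at the limit of > 100000 nM in this assay, at which 1 of the 3 values shown sits, and where it truly sits beyond that floor is not known. The steps of an at least 1.9-fold higher number from compound 1 to compound 3 (0.29 log units; that floor lies within the scatter) and an at least 1.1-fold higher number from compound 2 to compound 3 (0.06 log units; that floor lies within the scatter) both carry floors that lie within the scatter, so nothing sets compound 3 apart from compound 1 or compound 2 on the numbers shown.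

Compound 4 `N#Cc1ccc(Nc2nc(Oc3ccnc4ccccc34)nc(N3CCN(c4ccccc4F)CC3)n2)cc1C(F)(F)F` differs from compound 3 in one place: 2-fluorophenyl in place of 4-methoxyphenyl on an amine nitrogen in a ring. For the measured compounds named here, no measured pair exchanges one aryl group for another on that ring nitrogen; the only steps that reach that nitrogen replace a small alkyl with an aryl and give no change beyond the scatter. With the starting point itself only a limit, the expectation for compound 4 rests on weak ground. Compound 4 is expected to give 150000 nM, within a range from 60000 nM to 400000 nM, most likely reported again as a limit. The expected step is a step that the limit leaves unreadable from compound 3 to compound 4, none beyond the scatter.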

Compound 4, concentration for 50% growth inhibition: > 100000 nM
Compound 4: only a limit was reported; the forecaster's own chance of this, stated with the estimate: 70%; the middle value lies beyond the limit too.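

With compound 4, a second aryl group on the amine nitrogen in the ring ends at a limit of this assay, so this outcome is not confined to 4-methoxyphenyl: the limit of > 100000 nM in this assay, at which 2 of the 4 values shown sit.

The exchange of 4-methoxyphenyl for 2-fluorophenyl cannot itself be read, as compound 3 and compound 4 both carry only limits. The remaining steps, an at least 1.1-fold higher number from compound 2 to compound 4 (0.06 log units; that floor lies within the scatter) and an at least 1.9-fold higher number from compound 1 to compound 4 (0.29 log units; that floor lies within the scatter), carry floors that lie within the scatter, so 2-fluorophenyl, like 4-methoxyphenyl, is not set apart on these numbers from the small alkyl groups of compound 1 and compound 2.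

Where compound 3 and compound 4 truly sit beyond the limit remains unknown, and so does whether an aryl group on this nitrogen differs at all from methyl or ethyl in this assay. From the compounds shown here alone, it is also open whether a benzyl group or a 2-hydroxyethyl chain on the same nitrogen would give a value that can be read, and so show a real difference from the groups seen here.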